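Working notes: from compound 3 to compound 4

The compounds below may be only part of what the source reports. "The series", "measured", "known", "first", "only" and "open" are said of these compounds alone.

Values in a physicochemical assay for lipophilicity, measured as octanol-water partition (on this read-out lower numbers stand for lower lipophilicity and higher numbers for higher lipophilicity), so far
compound 1 `CCCCCc1cn(C/C=C(\C)CCC=C(C)C)nn1` gives 5.45
compound 2 `CC(C)=CCC/C(C)=C/Cn1cc(-c2ccccc2)nn1` gives 4.91
compound 3 `COC(=O)c1cn(CC=C(C)C)nn1` gives 1.3

Compound 3 at 1.3 is the lowest of the three, beyond the scatter from both of the others. Compound 4 `COC(=O)c1cn(C/C=C(\C)CCC=C(C)C)nn1` is the next case, and its change from compound 3 is 3-methylbut-2-en-1-yl in place of hydrogen on a saturated chain carbon bound to a double-bonded chain carbon with nothing else altered. For the measured compounds named here, the only measured step is a number 0.54 log units lower from compound 1 to compound 2 (beyond the scatter) and it is modest though beyond the scatter. That step concerns phenyl in place of pentyl on an aromatic carbon, not the present place, so it gives no direct size here. Going by the values given here, no measured pair isolates the present change. Compound 1 at 5.45 and compound 2 at 4.91 both carry the chain of compound 4 and both stand well above compound 3, yet they also differ from it in the group on the aromatic carbon, so that gap is not the size of this step. In this assay a clear rise is therefore expected, larger than the modest measured step and well beyond the scatter, but short of that gap. The expected step is a number 1.90 log units higher from compound 3 to compound 4 (beyond the scatter) in size. The estimate for compound 4 is 3.2 with an expected range from 2.7 to 3.7 in this measurement.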

Compound 4, partition coefficient: 3.2
Compound 4: middle estimate and measured number agree at the digits printed; the range from low to high includes it.
By their numbers in this assay, from the lowest: compound 3; then compound 4; then compound 2; then compound 1.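

In this assay, the chain position now has a measured size of its own: 3-methylbut-2-en-1-yl in place of hydrogen on a saturated chain carbon bound to a double-bonded chain carbon gives a number 1.90 log units higher from compound 3 to compound 4 (beyond the scatter), a large step at a place the earlier pair did not touch. With that chain held constant, the aromatic carbon also proves more responsive than the earlier pair showed: methoxycarbonyl in place of phenyl gives a number 1.71 log units lower from compound 2 to compound 4 (beyond the scatter), and methoxycarbonyl in place of pentyl gives a number 2.25 log units lower from compound 1 to compound 4 (beyond the scatter), both large, whereas the step between the two earlier groups is only modest at a number 0.54 log units lower from compound 1 to compound 2 (beyond the scatter). No supporting data bear on the sizes of these steps.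

From the compounds shown here alone, the chain step is known only with methoxycarbonyl on the aromatic carbon, so its size with phenyl or pentyl there remains open, as does whether the two places add up. Also open, going by these compounds, is where a carboxylic acid or an amine on the aromatic carbon, or a longer chain in place of 3-methylbut-2-en-1-yl, would fall in this assay.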